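This account rests on a few compounds, and the source may have more. Where it says the series, first, only, none or still open, it means among the compounds named here.

Compound 1 `COc1cccc(-c2c(S(=O)(=O)c3ccc(OC)c(Cl)c3)cnc3cc(F)ccc23)c1` is one of three compounds whose numbers in an ADME assay on microsomes from liver (Homo sapiens) for metabolic stability, tested at 2.5 uM (on this read-out higher numbers stand for fast clearance and lower numbers for slow clearance), are known. In this assay compound 1 gives 1.71 mL/min. Among the compounds with values here, its nearest neighbour is compound 2 `COc1ccc(-c2c(S(=O)(=O)c3cccc(F)c3)cnc3cc(F)ccc23)cc1`, which gives 1.89 mL/min in this assay; compound 2 differs from compound 1 in more than one place, so no single step is drawn between them, and their two values lie within the scatter of each other. Compound 3 `COc1ccc(S(=O)(=O)c2cnc3cc(F)ccc3c2-c2ccc(F)cc2)cc1Cl` gives 1.29 mL/min in this assay, and the one-place step from compound 1 to compound 3 is a 1.3-fold lower number from compound 1 to compound 3 (0.12 log units; within the scatter), a change that leaves the sulfonyl-bearing ring untouched. Compound 1 thus sits among three numbers that are all within the scatter of one another.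

Compound 4 `COc1cccc(-c2c(S(=O)(=O)c3cc(F)cc(F)c3)cnc3cc(F)ccc23)c1` has not yet been measured in this assay. It differs from compound 1 as follows: 3,5-difluorophenyl in place of 3-chloro-4-methoxyphenyl on a sulfonyl sulfur. Within the data shown here, no measured step touches the ring on the sulfonyl sulfur, so the only bearing the data have is that the one measured step, a 1.3-fold lower number from compound 1 to compound 3 (0.12 log units; within the scatter), stayed within the scatter. Compound 4 is therefore expected to show a step of about a 1.0-fold lower number from compound 1 to compound 4 (0.00 log units; within the scatter), that is, none beyond the scatter. The estimate for compound 4 is 1.7 mL/min, with a range from 1 mL/min to 2.9 mL/min.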

Compound 4, intrinsic clearance in a liver preparation (reported as CLH), per the amount of preparation that the assay uses: 1.81 mL/min
The estimate for compound 4 lay 1.1-fold (0.03 log units) below the measured number, within the range that was stated.
By their numbers in this assay, from the lowest: compounds 3, 1, 4 and 2 (each within the scatter of the next).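

Within the data shown here, the ring on the sulfonyl sulfur, which no earlier step had touched, now has a measured step in this assay: a 1.1-fold higher number from compound 1 to compound 4 (0.02 log units; within the scatter). At this place, 3,5-difluorophenyl and 3-chloro-4-methoxyphenyl cannot be told apart on this read-out, even though the group that enters carries only fluorine as substituent atoms and the group that leaves carries a chlorine and a methoxy oxygen. This holds for this one pair alone, and no measurement at hand offers any reason for it.

From the compounds shown here alone, whether an amine or a carboxylic acid on the ring at the sulfonyl sulfur would also stay within the scatter remains open. Also open, going by these compounds, is whether the same replacement would give a similar step with the 4-fluorophenyl of compound 3 on the aromatic carbon.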